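The compounds below may be only part of what the source reports. "The series", "measured", "known", "first", "only" and "open" are said of these compounds alone.

Measured in a functional assay on PC-3 cells (Homo sapiens) for cytotoxicity; a higher number here means a weaker inhibitor, a lower number a stronger inhibitor:

- compound 1 `Oc1ccc(/C=N/n2cnnc2)cc1`: > 30000 nM, a limit
- compound 2 `CCOc1cccc(/C=N/n2cnnc2)c1O`: > 30000 nM, a limit
- compound 3 `COc1ccc(/C=N/n2cnnc2)cc1`: > 30000 nM, a limit

None of these three entries is a true number, so the series offers no ranking. The picture is a single shared result: the limit of > 30000 nM in this assay, at which 3 of the 3 values shown sit.

Compound 3 is the starting point here. Compound 3 has only a limit to its name, > 30000 nM, and the other two compounds offer nothing firmer to compare it with.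

Compound 4 `Brc1ccc(/C=N/n2cnnc2)cc1` keeps the rest of compound 3 and carries bromo in place of methoxy on an aromatic carbon, para to a group of 7 heavy atoms: bromo in place of methoxy on an aromatic carbon.

Among the measured compounds shown here, the one measured step that bears on this change is a step that the two limits leave unreadable from compound 1 to compound 3. It involves the oxygen that leaves in the new change, but it has no readable size to carry over. The data therefore give no support for expecting a step beyond the scatter in either direction in this assay, and the most likely outcome is another limit.

The expected step is a number no higher from compound 3 to compound 4 (the limit leaves the size open).

The estimate for compound 4 is 30000 nM, with an expected range from 12000 nM to 60000 nM.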

Compound 4, half-maximal inhibitory concentration: > 30000 nM
Compound 4: no number, only a limit (the forecaster's own chance of this, stated with the estimate: 75%); the middle value lies on the limit itself.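

Compound 4 gives > 30000 nM, which is a limit and not a number. Its steps from compound 1 and from compound 3 therefore cannot be read. Whether any of these changes shifts the result in this assay at all stays open, because every compound shown ends at the same point: the limit of > 30000 nM in this assay, at which 4 of the 4 values shown sit.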